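Solubility notes on a two-ring amine series

The source may report more compounds than this note shows. Statements on the series, on what has been measured and on what is new or still open speak of the compounds shown alone.

Measured compounds:
compound 1 `COc1ccc(-c2c(C)nn3c(NCc4ccccn4)cc(C)nc23)cc1` — < 5000 nM
compound 2 `COc1ccc(-c2cnn3c(NCc4ccccn4)cc(C)nc23)cc1` — < 5000 nM

In a physicochemical assay for solubility, read by HPLC, using the shake flask method, measured as kinetic solubility, with a stated time of 2 h, at pH 7.4 (on this read-out higher numbers stand for higher solubility and lower numbers for lower solubility), compound 1 gives < 5000 nM, which is a limit of the assay and not a number. Compound 2 likewise gives only a limit, < 5000 nM. The step that the two limits leave unreadable from compound 1 to compound 2 is therefore unreadable, as both values sit at the limit of < 5000 nM in this assay, at which 2 of the 2 values shown sit. Compound 3 `Cc1cc(NCc2ccccn2)n2nc(C)cc2n1` differs from compound 1 by hydrogen in place of 4-methoxyphenyl on an aromatic carbon. Among the measured compounds shown here, no measured step covers this change, and the single measured step carries no size, so the expectation rests on little. Compound 3 is expected to reach about 10000 nM, with a range of 2000 nM to 50000 nM. The expected step is an at least 2.0-fold higher number from compound 1 to compound 3 (0.30 log units; that floor lies within the scatter).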

Compound 3, solubility: > 200000 nM
Compound 3: a limit, no number (the forecaster's own chance of this, stated with the estimate: 40%); middle value at least 20-fold (1.30 log units) from the limit.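

In this assay, among the compounds shown here, hydrogen in place of 4-methoxyphenyl on this aromatic carbon gives an at least 40-fold higher number from compound 1 to compound 3 (1.60 log units; beyond the scatter), the first readable step. The step between the two earlier compounds cannot be read, so that change at the other place offers no size to set beside this one. Compound 3 gives a limit of the assay, not a number: the limit of > 200000 nM in this assay, at which 1 of the 3 values shown sits.

On these data alone, the full size of the step therefore stays open. Also open, as far as these compounds go, is how a plain phenyl, an amine or a carboxylic acid at this place would compare with 4-methoxyphenyl and hydrogen.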